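A few compounds are considered here, and "the series" means these few. Any claim that something is new, unique, unknown or untested is made for them only; others in the source may bear on it.

Compound 1 `Cc1ccc(S(=O)(=O)N(C)CC(C)C)cc1C#Cc1cc(Cl)ccc1OCC(=O)O` gives 4.2 nM in an assay on CHO cells for displacement of a labelled ligand from prostaglandin D2 receptor 2 (Homo sapiens), read by scintillation counting; a lower number here means a stronger inhibitor, a higher number a weaker inhibitor. For the measured compounds named here, it stands lowest of the two numbers measured so far; compound 2 `CCCCCCc1ccncc1C#Cc1cc(Cl)ccc1OCC(=O)O` gives 43 nM in this assay, a higher number by a gap beyond the usual scatter. Compound 3 `Cc1ccc(S(=O)(=O)NC(C)(C)C)cc1C#Cc1cc(Cl)ccc1OCC(=O)O` has not yet been measured. It differs from compound 1 in a single place: (tert-butyl)amino in place of isobutyl(methyl)amino on a sulfonyl sulfur. Going by the values given here, no measured pair shows the effect of this kind of change, so the step is uncertain; only a small shift, within or barely beyond the scatter, is expected. Compound 3 is therefore estimated at 6 nM, with a likely range from 2 nM to 20 nM, which would mean an expected step of a 1.4-fold higher number from compound 1 to compound 3 (0.15 log units; within the scatter).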

Compound 3, inhibition constant: 5 nM
Compound 3: the middle estimate sits 1.2-fold (0.08 log units) above what was measured; the range from low to high includes it.
By their numbers in this assay, from the lowest: compounds 1 and 3 (each within the scatter of the next); then compound 2.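

In this assay, the step is a 1.2-fold higher number from compound 1 to compound 3 (0.08 log units; within the scatter), so the two compounds cannot be told apart. The sulfonyl sulfur can therefore carry either isobutyl(methyl)amino, with no hydrogen-bond donor, or (tert-butyl)amino, with one, and the numbers remain within the scatter of each other, something compound 2 could not show. Nothing measured here gives a reason for this result. Still open, going by these compounds, is how a much smaller group such as dimethylamino, or a ring such as morpholine, would fare on the same sulfur.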